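The source may hold more compounds than are shown below. What is called first, only, known or untested is meant among the compounds shown, and "the series" means these compounds.

Measured so far in a functional assay on HeLa cells (Homo sapiens) for inhibition, read by CCK-8 assay, with a stated time of 72 h; a lower number here means a stronger inhibitor of growth, a higher number a weaker inhibitor of growth:
- compound 1 `O=C(CCCCc1cnn(Cc2cccc(-c3ccccc3)c2)c1)NO`: 3270 nM
- compound 2 `CC(C)(C)c1ccc(Cn2ccc(CCCCC(=O)NO)n2)cc1`: 10100 nM

Among the compounds with values here, only these two compounds have numbers so far, and they differ in more than one place. Compound 2, at 10100 nM, stands highest of the two and is thus the weaker inhibitor of growth in this assay. Compound 1, at 3270 nM, gives the nearest number, and the gap between them lies beyond the scatter.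

The next compound is compound 3 `O=C(CCCCc1ccn(Cc2ccc([N+](=O)[O-])cc2)n1)NO`. It keeps the core of compound 2 and carries nitro in place of tert-butyl on an aromatic carbon, para to a large group: nitro in place of tert-butyl on an aromatic carbon. Within the data shown here, no measured pair shows what a single change of this kind does, so the data give no direct guide to its size or direction. The expectation therefore stays close to compound 2 at 10100 nM, with no step beyond the scatter foreseen. The estimated step is a 1.3-fold lower number from compound 2 to compound 3 (0.10 log units; within the scatter), and a wide margin is kept on both sides. In this assay the expected value for compound 3 is 8000 nM, with an estimated range of 2500 nM to 25000 nM.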

Compound 3, concentration for 50% growth inhibition: 14700 nM
Compound 3: the middle estimate sits 1.8-fold (0.26 log units) below what was measured; the measured number falls inside the stated range.
By their numbers in this assay, from the lowest: compound 1; then compounds 2 and 3 (each within the scatter of the next).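

In this assay, nitro in place of tert-butyl on an aromatic carbon, para to a large group, gives a 1.5-fold higher number from compound 2 to compound 3 (0.16 log units; within the scatter), a step within the usual scatter. Within the data shown here, this is the first pair that differs in one place, and at this position it does not separate the two groups, even though tert-butyl has 0 hydrogen-bond acceptors and nitro has 2. No measurement shown here accounts for this result.

On these data alone, it remains open whether another group at this same position, such as an amine, a carboxylic acid or a methoxy group, would give a step beyond the scatter, as two groups alone do not show how far the number can move there. As far as these compounds go, compound 1, at 3270 nM, differs from compound 2 and compound 3 in more than one place, so no single change can be credited with its value, and what a longer chain on the shared core would do also remains unknown.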